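The source may report more compounds than this note shows. Statements on the series, on what has been measured and on what is new or still open speak of the compounds shown alone.

Measured set in a functional assay on L1210 cells (Mus musculus) for antiproliferative activity; on this read-out higher numbers stand for weaker inhibition and lower numbers for stronger inhibition:

Compound 1 `CSc1nc2c(C)nsc2n1[C@H]1C[C@H](O)[C@@H](CO)O1`. In this assay compound 1 gives > 100000 nM, which is a limit of the assay and not a number.

Compound 2 `Cc1nsc2c1nc(SCc1ccccc1)n2[C@H]1C[C@H](O)[C@@H](CO)O1`. In this assay compound 2 gives > 100000 nM, likewise a limit of the assay.

Among the compounds with values here, the single one-place step among the measured pair, a step that the two limits leave unreadable from compound 1 to compound 2, cannot be sized because of the limit of > 100000 nM in this assay, at which 2 of the 2 values shown sit. Within the data shown here, compound 2 therefore stands at the limit, and its one companion value is a limit as well, so no ordering can be read.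

Compound 3 `Cc1nsc2c1nc(SCc1ccccc1)n2[C@@H]1O[C@H](CO)[C@@H](O)[C@H]1O` differs from compound 2 by hydroxy in place of hydrogen on a saturated ring carbon. Among the measured compounds shown here, no measured step touches this place, and the only step on record, a step that the two limits leave unreadable from compound 1 to compound 2, is unreadable in any case, so nothing measured bears on the change. With both recorded values at the limit, the expectation is that compound 3 also returns no number in this assay, the step that the limit leaves unreadable from compound 2 to compound 3 being expected to lie within the scatter. Compound 3 is accordingly estimated at 150000 nM, with a range from 50000 nM to 500000 nM, most likely reported only as a limit.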

Compound 3, half-maximal inhibitory concentration: > 100000 nM
Compound 3: no number, only a limit; the forecaster's own chance of this, stated with the estimate: 80%; the middle value lies beyond the limit too.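

In this assay compound 3 gives > 100000 nM, a limit of the assay and not a number. No step between compound 1, compound 2 and compound 3 can be read, because all the values sit at the same limit: the limit of > 100000 nM in this assay, at which 3 of the 3 values shown sit.

The compounds shown leave open whether either change on the shared core alters inhibition at all.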